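Adding a Methyl to the Oxetane Ring of Compound 2

A few compounds are considered here, and "the series" means these few. Any claim that something is new, unique, unknown or untested is made for them only; others in the source may bear on it.

Of the compounds shown here, two sharing one core have been tested in a functional assay on cells for antagonist activity at Free fatty acid receptor 1 (Homo sapiens), read by TR-FRET and inositol phosphate accumulation, with a stated time of 2 h; on this read-out lower numbers stand for stronger inhibition and higher numbers for weaker inhibition. Compound 1 `Fc1ccc(OCc2cc(N3CC4(CCO4)C3)nc(-c3ccccn3)n2)c(F)c1F` gives 501 nM, and compound 2 `Fc1ccc(OCc2cc(OCC3COC3)nc(-c3ccccn3)n2)c(F)c1F` gives 316 nM; the step of a 1.6-fold lower number from compound 1 to compound 2 (0.20 log units; within the scatter) lies within the scatter, so the two numbers stand level. Compound 3 `CC1(COc2cc(COc3ccc(F)c(F)c3F)nc(-c3ccccn3)n2)COC1` differs from compound 2 by methyl in place of hydrogen on a saturated ring carbon. Among the compounds with values here, the single measured step swaps one ring group for another and says nothing about a methyl on a saturated ring carbon, so no shift beyond the scatter is expected in this assay. Compound 3 is therefore estimated at 320 nM, with a range from 130 nM to 800 nM, an expected step of a 1.0-fold higher number from compound 2 to compound 3 (0.01 log units; within the scatter).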

Compound 3, half-maximal inhibitory concentration in the Free fatty acid receptor 1 assay: 79.4 nM
Estimate against measurement, compound 3: 4.0-fold (0.61 log units) above; measured number below the stated range.
By their numbers in the Free fatty acid receptor 1 assay, from the lowest: compound 3; then compounds 2 and 1 (each within the scatter of the next).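

In the Free fatty acid receptor 1 assay compound 2 gives 316 nM and compound 3 gives 79.4 nM, and the change from (oxetan-3-yl)methoxy to (3-methyloxetan-3-yl)methoxy gives a 4.0-fold lower number from compound 2 to compound 3 (0.60 log units; beyond the scatter) and so shows that this ring carbon responds to a single added methyl. Set against the group with two four-membered rings, the methylated group gives a 6.3-fold lower number from compound 1 to compound 3 (0.80 log units; beyond the scatter) and opens a gap that the earlier pair did not show. In a physicochemical assay for lipophilicity, at pH 7.4 (a higher number here means a more lipophilic compound, a lower number a more polar compound), compound 2 gives 3.7 and compound 3 gives 4, and the same methyl gives a number 0.30 log units higher from compound 2 to compound 3 (within the scatter) and nothing available here explains the gain.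

From the compounds shown here alone, whether ethyl or an amine on this same ring carbon would give a lower number stays open.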